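Phenyl for cyclohexylethyl on the imidazole of compound 3

This account rests on a few compounds, and the source may have more. Where it says the series, first, only, none or still open, it means among the compounds named here.

Of the compounds shown here, three sharing one core have been measured in an in vitro functional assay on cells for agonist activity at Bombesin receptor subtype-3 (Homo sapiens), read by luminescence and calcium flux; a lower number here means that less compound is needed, a higher number that more compound is needed for the effect. Compound 1 `O=C(O)c1ccccc1-c1ccc(CCc2ncc(CC3CCC3)[nH]2)cc1` gives 588 nM, compound 2 `O=C(O)c1ccccc1-c1ccc(CCc2ncc(C3CCCCC3)[nH]2)cc1` gives 375 nM, and compound 3 `O=C(O)c1ccccc1-c1ccc(CCc2ncc(CCC3CCCCC3)[nH]2)cc1` gives 642 nM. Compound 3 holds the highest of the three numbers, though the step of a 1.1-fold higher number from compound 1 to compound 3 (0.04 log units; within the scatter) and the step of a 1.7-fold higher number from compound 2 to compound 3 (0.23 log units; within the scatter) both lie within the scatter, so on the numbers alone it stands level with both.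

Compound 4 `O=C(O)c1ccccc1-c1ccc(CCc2ncc(-c3ccccc3)[nH]2)cc1` differs from compound 3 in one place: phenyl in place of 2-cyclohexylethyl on an aromatic carbon. The steps already seen at this same position bear directly on the change. The step of a 1.6-fold lower number from compound 1 to compound 2 (0.20 log units; within the scatter) and the step of a 1.7-fold higher number from compound 2 to compound 3 (0.23 log units; within the scatter) both fall within the scatter, as does a 1.1-fold higher number from compound 1 to compound 3 (0.04 log units; within the scatter); across cyclobutylmethyl, cyclohexyl and 2-cyclohexylethyl the read-out barely moves. For the measured compounds named here, a phenyl group has not yet been tried here, but nothing among the measured steps points to a shift beyond the scatter in this assay, in either direction.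

Compound 4 is therefore expected to show 600 nM in this assay, within a range from 250 nM to 1500 nM, which is estimated to mean a step of a 1.1-fold lower number from compound 3 to compound 4 (0.03 log units; within the scatter).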

Compound 4, half-maximal effective concentration: 4950 nM
Beside the measured number, compound 4's estimate is 8.3-fold (0.92 log units) below it; the measured number lies above the stated range.
By their numbers in this assay, from the lowest: compounds 2, 1 and 3 (each within the scatter of the next); then compound 4.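

In this assay this position, an aromatic carbon of the five-membered aromatic ring with 2 nitrogen, had taken cyclobutylmethyl, cyclohexyl and 2-cyclohexylethyl with every step inside the scatter, but it does not take every hydrocarbon ring alike: phenyl brings a 7.7-fold higher number from compound 3 to compound 4 (0.89 log units; beyond the scatter) and a 13-fold higher number from compound 2 to compound 4 (1.12 log units; beyond the scatter) and also an 8.4-fold higher number from compound 1 to compound 4 (0.93 log units; beyond the scatter) as steps that all lie clearly beyond the scatter. The cyclohexyl to phenyl pair is the closest comparison, since both groups are one six-membered ring of carbon only attached directly to the same place, so ring size and direct attachment alone do not preserve the read-out, and the aromatic ring is what separates compound 4 from compound 2. Nothing available explains why the aromatic group behaves so differently here.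

The compounds shown cannot tell whether the loss belongs to any aromatic ring at this position or only to one attached directly, a question that a benzyl or 2-phenylethyl group would address. On these data alone, it also remains open whether a pyridine ring, or a phenyl ring carrying a fluorine or a methoxy group, would behave like compound 4 or like compound 2.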